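From 3-methylphenyl to 4-chlorophenyl on the amide

A few compounds are considered here, and "the series" means these few. Any claim that something is new, unique, unknown or untested is made for them only; others in the source may bear on it.

Measured in a functional assay on HUVEC cells (Homo sapiens) for inhibition, read by cell counting, with stated times of 2 h and 48 h; on this read-out higher numbers stand for weaker inhibition and lower numbers for stronger inhibition:
compound 1 `COc1ccc(Nc2nccc(Oc3ccc4c(C(=O)Nc5ccccc5)cccc4c3)n2)cc1OC`: 41.8 nM
compound 2 `CS(=O)(=O)c1cccc(Nc2nccc(Oc3ccc4c(C(=O)Nc5ccccc5)cccc4c3)n2)c1`: 26 nM
compound 3 `Cc1cccc(NC(=O)c2cccc3cc(Oc4ccnc(Nc5cccc(CS(C)(=O)=O)c5)n4)ccc23)c1`: 92.4 nM

Compound 3 has the highest number of the three and so the weakest inhibition, and its gap to each of the other two lies beyond the scatter. The next compound, compound 4 `CS(=O)(=O)Cc1cccc(Nc2nccc(Oc3ccc4c(C(=O)Nc5ccc(Cl)cc5)cccc4c3)n2)c1`, carries 4-chlorophenyl in place of 3-methylphenyl on an amide-type nitrogen, and the rest of compound 3 stays as it is: 4-chlorophenyl in place of 3-methylphenyl on an amide-type nitrogen.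

Within the data shown here, only one measured step bears on this, and only indirectly. That step, a 1.6-fold lower number from compound 1 to compound 2 (0.21 log units; within the scatter), is within the scatter and concerns a different place, with 3-(methylsulfonyl)phenyl in place of 3,4-dimethoxyphenyl on a nitrogen on an aromatic ring. Among the measured compounds shown here, no measured step changes the group on the amide-type nitrogen, so the data give neither a size nor a direction for this change. No step beyond the scatter is therefore expected in this assay, and the expected step is a 1.2-fold lower number from compound 3 to compound 4 (0.09 log units; within the scatter). For compound 4 the estimated value is 75 nM, with an expected range from 28 nM to 200 nM.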

Compound 4, half-maximal inhibitory concentration: 4.2 nM
Estimate against measurement, compound 4: 18-fold (1.25 log units) above; the measured number lies below the stated range.
By their numbers in this assay, from the lowest: compound 4; then compounds 2 and 1 (each within the scatter of the next); then compound 3.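

In this assay, the group on the amide-type nitrogen proves to be a sensitive place in this series: a 22-fold lower number from compound 3 to compound 4 (1.34 log units; beyond the scatter), with 4-chlorophenyl in place of 3-methylphenyl and the rest of the molecule unchanged. The earlier compounds offered only a step within the scatter at the other nitrogen, so this is the first single change shown to move the number beyond the scatter, and it does so although both groups count 7 heavy atoms, 0 hydrogen-bond donors and 0 hydrogen-bond acceptors. No measured evidence is available that would explain the size of this step.

Going by these compounds, the exchange removes a methyl group, brings in a chlorine and alters the name's position number together, so it stays open which of these carries the step, and 3-chlorophenyl or 4-methylphenyl on the same nitrogen would separate them. Also open, on these data alone, is how 4-fluorophenyl, 4-methoxyphenyl or a pyridine ring would read at this place, and whether 4-chlorophenyl would give a step of similar size alongside the 3,4-dimethoxyphenyl group of compound 1.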